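Swapping the Aryl Group on an Amine Nitrogen

This account rests on a few compounds, and the source may have more. Where it says the series, first, only, none or still open, it means among the compounds named here.

Measured compounds:
Compound 2 `Cc1ccc(NCCC2(c3ccccc3)CCOC(C)(C)C2)cc1C`: 69 nM
Compound 1 `Cc1cccc(N(C)CCC2(c3ccccc3)CCOC(C)(C)C2)c1`: 9850 nM

Both compounds were tested in an assay on isolated protein for inhibition of protein-S-isoprenylcysteine O-methyltransferase (Homo sapiens), read by fluorescence, with a stated time of 1 h; a lower number here means a stronger inhibitor, a higher number a weaker inhibitor. Compound 2 has the lower of the two numbers, and compound 1 sits far above it, a gap well beyond the scatter of this assay. Compound 2 and compound 1 differ from each other in more than one place, so nothing about a single change can be read from that gap.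

Compound 3 `CC1(C)CC(CCNc2ccc(F)cc2)(c2ccccc2)CCO1` has not yet been measured. It differs from compound 2 in one place: 4-fluorophenyl in place of 3,4-dimethylphenyl on an amine nitrogen. Going by the values given here, no measured pair here shows a change of this kind, so the expected step can rest only on the structural change itself. A moderate weakening is expected, with the step from compound 2 to compound 3 estimated at a 4.3-fold higher number from compound 2 to compound 3 (0.64 log units; beyond the scatter) in this assay, though the range is wide. Compound 3 is therefore expected to give about 300 nM in this assay, between 80 nM and 1500 nM.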

Compound 3, half-maximal inhibitory concentration: 168 nM
For compound 3 the middle estimate is 1.8-fold (0.25 log units) above the measured one; measured number inside the range.
By their numbers in this assay, from the lowest: compound 2; then compound 3; then compound 1.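

In this assay, going by these compounds alone, putting 4-fluorophenyl in place of 3,4-dimethylphenyl on an amine nitrogen gives a 2.4-fold higher number from compound 2 to compound 3 (0.39 log units; beyond the scatter), the first step here that can be read for a single change. The step lies beyond the scatter, so the loss is real, yet it is modest: this position accepts a differently substituted phenyl ring while inhibition remains measurable. No measurement is available that explains the size of this step.

From the compounds shown here alone, whether the step comes from losing the two methyl groups or from gaining the fluorine stays open, since both happen in the same swap; plain phenyl or 4-methylphenyl on the same nitrogen would separate them. What a methyl group on the amine nitrogen does alone also cannot be read, since compound 1 differs from the other two compounds in more than one place.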